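Moving the Fluorine on the Phenyl Ring

The source may hold more compounds than are shown below. What is called first, only, known or untested is meant among the compounds shown, and "the series" means these compounds.

Measured compounds:
compound 1, `Cc1nc(C)c(C(=O)Nc2ccc(F)c(-c3nc4ncc(-c5cccnc5Cl)cn4n3)c2)o1`, > 50000 nM
compound 2, `O=C(Nc1ccc(F)c(-c2nc3ncc(-c4cccc(F)c4)cc3[nH]2)c1)N1CCCC1`, 28200 nM

The account concerns an ADME assay on HepG2 cells (Homo sapiens) for cytotoxicity, read by resazurin assay, with a stated time of 48 h; a higher number here means that more compound is needed for the effect, a lower number that less compound is needed. Compound 1 `Cc1nc(C)c(C(=O)Nc2ccc(F)c(-c3nc4ncc(-c5cccnc5Cl)cn4n3)c2)o1` reports only a limit in this assay, > 50000 nM, and not a number. Compound 2 `O=C(Nc1ccc(F)c(-c2nc3ncc(-c4cccc(F)c4)cc3[nH]2)c1)N1CCCC1` gives 28200 nM, which is the only number shown. Among the measured compounds shown here, the one further value, that of compound 1, is a limit, described by the limit of > 50000 nM in this assay, at which 1 of the 2 values shown sits. So compound 2 stands as the single measured point from which any expectation has to start.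

Compound 3 `O=C(Nc1ccc(F)c(-c2nc3ncc(-c4ccccc4F)cc3[nH]2)c1)N1CCCC1` is not yet measured. It differs from compound 2 in a single place: 2-fluorophenyl in place of 3-fluorophenyl on an aromatic carbon. The two have the same atoms, joined differently, so nothing is added or removed.

For the measured compounds named here, no pair of measured compounds that differ in one place is available, so the size of such a step in this assay is not known here. For a change of this kind, with the same atoms joined differently, a step beyond the scatter is not expected in either direction. Compound 3 is therefore estimated at 30000 nM, within 12000 nM to 70000 nM, which means a step of a 1.1-fold higher number from compound 2 to compound 3 (0.03 log units; within the scatter) that is expected to stay within the scatter.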

Compound 3, half-maximal effective concentration: > 50000 nM
Compound 3: a limit, no number; the forecaster's own chance of this, stated with the estimate: 35%; at least 1.6-fold (0.22 log units) between middle value and limit.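

Among the compounds shown here, the change from 3-fluorophenyl to 2-fluorophenyl, on an aromatic carbon two atoms from the ring nitrogen, is the first change in one place that can be read in this assay, and it comes to an at least 1.7-fold higher number from compound 2 to compound 3 (0.24 log units; that floor lies within the scatter). This gives the position something compound 1 and compound 2 could not give on their own, a lower bound for a step, although that floor lies within the scatter, so the data do not establish that moving the fluorine shifts the number, and they set no upper bound on how large the step might be. The reading for compound 3 is a limit and not a number, which leaves compound 2 as the only compound with a measured number and gives the step no fixed size: the limit of > 50000 nM in this assay, at which 2 of the 3 values shown sit.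

Going by these compounds, what stays open is how far the number can move at this position, and whether any compound carrying this core falls well below the number of compound 2. An amine or a carboxylic acid on the phenyl ring in place of the fluorine would test this position with a group of another kind, and the compounds shown say nothing about either.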